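Triazine series: methoxybenzyl change carried onto the fluoro core

The source may hold more compounds than are shown below. What is called first, only, known or untested is meant among the compounds shown, and "the series" means these compounds.

Measured so far:
compound 1, `Cc1cccc(CNc2nc(N)nc(-c3ccccc3CO)n2)c1`, 4.4
compound 2, `COc1ccccc1CNc1nc(N)nc(-c2ccccc2CO)n1`, 3.99
compound 3, `Cc1cccc(CNc2nc(N)nc(-c3c(F)cccc3CO)n2)c1`, 4.44

In a functional assay on cells for positive allosteric modulation of G-protein coupled receptor 68 (Homo sapiens), read by a luciferase reporter and cAMP accumulation, with a stated time of 30 min, at pH 6.8 and pH 8.3, in the presence of a further agent that is not named here (a higher number here means a more potent compound, by a factor of ten per unit of this negative logarithm, a lower number a less potent compound), compound 1 gives 4.4, and two single changes branch from it. The first is 2-methoxyphenyl in place of 3-methylphenyl on a saturated chain carbon bound to a nitrogen on an aromatic ring; the step it made is a number 0.41 log units lower from compound 1 to compound 2 (beyond the scatter). The second is fluoro in place of hydrogen on an aromatic carbon; the step it made is a number 0.04 log units higher from compound 1 to compound 3 (within the scatter). Compound 3 stands at 4.44, within the scatter of compound 1, while compound 2 sits beyond the scatter below both.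

Compound 4, `COc1ccccc1CNc1nc(N)nc(-c2c(F)cccc2CO)n1`, is not yet measured. It differs from compound 3 by 2-methoxyphenyl in place of 3-methylphenyl on a saturated chain carbon bound to a nitrogen on an aromatic ring, the same change that turns compound 1 into compound 2, placed on the core of compound 3, which differs from the core of compound 1 by fluoro in place of hydrogen on an aromatic carbon. The place descriptions match word for word, so the change is taken as the same.

Expected step: a number 0.41 log units lower from compound 3 to compound 4 (beyond the scatter), set beside the measured one, a number 0.41 log units lower from compound 1 to compound 2 (beyond the scatter), because that step is the only precedent and the fluoro change itself left the number essentially unmoved, a number 0.04 log units higher from compound 1 to compound 3 (within the scatter). Compound 4 is therefore estimated at 4.03, with a range of 3.65 to 4.4.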

Compound 4, negative logarithm of the antagonist equilibrium constant: 4.11
The estimate for compound 4 lay 0.08 log units below the measured number; low and high end bracket the measured number.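

In this assay, the change from 3-methylphenyl to 2-methoxyphenyl gives a number 0.33 log units lower from compound 3 to compound 4 (beyond the scatter), so it carries over to the fluoro core with much the same size as on the core without fluoro: the same change on two cores in this assay, a number 0.41 log units lower (beyond the scatter) from compound 1 to compound 2 and a number 0.33 log units lower (beyond the scatter) from compound 3 to compound 4, 0.08 log units apart, within the scatter of two such steps. Read the other way, the fluoro change gives a number 0.12 log units higher from compound 2 to compound 4 (within the scatter), and it stays within the scatter with either aryl group in place: the same change on two cores in this assay, a number 0.04 log units higher (within the scatter) from compound 1 to compound 3 and a number 0.12 log units higher (within the scatter) from compound 2 to compound 4, 0.08 log units apart, within the scatter of two such steps. This shows the two changes behaving independently in one square of four compounds, but it does not show that the 2-methoxyphenyl step would hold on any other core, and it gives no reason for the lower number.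

The compounds shown leave open whether chloro or trifluoromethyl in place of fluoro would also leave the number unmoved. They also leave open how the series responds to an amine or a carboxylic acid in place of the hydroxymethyl group, or to a longer chain at the carbon bound to the ring nitrogen.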